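Swapping chloro for 1H-indol-3-yl on a side chain

The source may report more compounds than this note shows. Statements on the series, on what has been measured and on what is new or still open speak of the compounds shown alone.

In a functional assay on L5178Y cells (Mus musculus) for inhibition, read by MTT assay, with a stated time of 24 h (a higher number here means a weaker inhibitor, a lower number a stronger inhibitor), compound 3 `COc1cc(O)c2c(c1)O[C@H](c1ccc(OCC(O)CCl)cc1)CC2=O` gives >= 11300 nM as its reading, and this is a limit rather than a number. Compound 1 `O=C(N/N=C1\C[C@@H](c2ccc(O)cc2)Oc2cc(O)cc(O)c21)c1ccco1` gives >= 11300 nM as its reading, again a limit. Compound 2 `COc1cc(O)c2c(c1)O[C@H](c1ccc(O)cc1)C/C2=N\Nc1ccccc1` gives >= 11300 nM as its reading, also a limit. The shared picture is the limit of >= 11300 nM in this assay, at which 3 of the 3 values shown sit, and so no exact potency is known yet for any of the three.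

Compound 4 `COc1cc(O)c2c(c1)O[C@H](c1ccc(OCC(O)Cc3c[nH]c4ccccc34)cc1)CC2=O` keeps the core of compound 3 and alters the end of its side chain. The difference 1H-indol-3-yl in place of chloro on a saturated chain carbon, two bonds along the chain from an oxygen on a saturated carbon is 1H-indol-3-yl in place of chloro on a saturated chain carbon, two bonds along the chain from an oxygen on a saturated carbon.

Among the compounds with values here, no measured pair yet shows what a single change does here, so any expectation is uncertain. The expected step of an at least 1.4-fold lower number from compound 3 to compound 4 (0.14 log units; that floor lies within the scatter) is a modest one toward stronger inhibition in this assay and remains an estimate. For compound 4 the estimated value is 8000 nM with an expected range from 2500 nM to 25000 nM in this measurement.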

Compound 4, half-maximal inhibitory concentration: >= 11300 nM
Compound 4 was reported as a limit; the forecaster's own chance of this, stated with the estimate: 40%; at least 1.4-fold (0.14 log units) between middle value and limit.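

Both compound 3 and compound 4 are reported only as limits in this assay, so no step between them can be read: the limit of >= 11300 nM in this assay, at which 4 of the 4 values shown sit.

The compounds shown leave open how strongly each one inhibits, and whether 1H-indol-3-yl in place of chloro changes that at all.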